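Removing one chloro from a dichlorinated depsidone core

A few compounds are considered here, and "the series" means these few. Any claim that something is new, unique, unknown or untested is made for them only; others in the source may bear on it.

Compound 1, `CCCc1c(Cl)c(OC)c(Cl)c(O)c1Oc1c(Cl)c(O)c(Cl)c2c1C(=O)O[C@@H]2CC`: > 50000 nM in an ADME assay on MDCK cells (Canis lupus familiaris) for cytotoxicity, read by CellTiter-Glo, with a stated time of 40 h; a lower number here means that less compound is tolerated, a higher number that more compound is tolerated
Compound 2, `CCCc1c(Cl)c(O)c(Cl)c(OC)c1Oc1c(Cl)c(O)c(Cl)c2c1C(=O)O[C@@H]2CC`: > 100000 nM in this assay
Compound 3, `CCCc1cc(O)c(Cl)c(O)c1Oc1c(Cl)c(O)c(Cl)c2c1C(=O)O[C@@H]2CC`: > 100000 nM in this assay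

All three values shown are limits of this assay rather than numbers. For compound 1 the value is a limit. For compound 2 the value is also a limit, and compound 2 therefore stands at the same limit as one other compound in the set, as the limit of > 100000 nM in this assay, at which 2 of the 3 values shown sit, shows. For compound 3 the value is a limit as well. Among the measured compounds shown here, the remaining compound sits at a different limit, as the limit of > 50000 nM in this assay, at which 1 of the 3 values shown sits, shows, so no finished number is available for any compound, and no step between measured compounds can be sized.

Compound 4, `CCCc1c(Cl)c(O)cc(OC)c1Oc1c(Cl)c(O)c(Cl)c2c1C(=O)O[C@@H]2CC`, has not yet been measured in this assay. It differs from compound 2 in one place: hydrogen in place of chloro on an aromatic carbon. Since compound 2 gave only a limit, the step from compound 2 to compound 4 in this assay is expected to be none beyond the scatter, and the most likely outcome is another limit. On that basis compound 4 is expected to give about 100000 nM, in a range from 50000 nM to 200000 nM, which corresponds to an expected step of a number no higher from compound 2 to compound 4 (the limit leaves the size open).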

Compound 4, half-maximal cytotoxic concentration: > 100000 nM
Compound 4: a limit, no number; the forecaster's own chance of this, stated with the estimate: 85%; the middle value sits exactly at the limit.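

In this assay compound 4 gives > 100000 nM, a limit and not a number. Compound 2 also stands at a limit, so the step between compound 2 and compound 4 cannot be read. The compounds shown leave open at what concentration any of them becomes cytotoxic, and whether hydrogen in place of chloro shifts that concentration at all.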